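The compounds below may be only part of what the source reports. "The series", "measured", "known", "first", "only" and "open" are said of these compounds alone.

Series notes, step from compound 2 to compound 4.

For the measured compounds named here, the three measured members share one core. Compound 1 `O=C/C=C/c1ccccc1OCc1ccccc1` gives 6400 nM in a functional assay on cells (Neutrophil, Rattus norvegicus, strain Sprague-Dawley) for inhibition; on this read-out higher numbers stand for weaker inhibition and lower numbers for stronger inhibition. Compound 2 `O=C/C=C/c1ccccc1OCc1ccc(Cl)cc1` gives 7400 nM in this assay, the highest of the three numbers, with compound 1 nearest and compound 3 furthest, both gaps within the scatter. Compound 3 `O=C/C=C/c1ccccc1OCc1cccc(F)c1` gives 4500 nM in this assay.

Compound 4 `Cc1ccc(COc2ccccc2/C=C/C=O)cc1` is not yet measured. From compound 2 it differs in one place: methyl in place of chloro on an aromatic carbon.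

Going by the values given here, two measured steps bear on substitution of the same benzyl ring. The step of a 1.2-fold higher number from compound 1 to compound 2 (0.06 log units; within the scatter) and the step of a 1.4-fold lower number from compound 1 to compound 3 (0.15 log units; within the scatter) both stay within the scatter, so a single small group on that ring has so far not moved the number beyond the scatter in either direction. Among the compounds with values here, no measured step exchanges one substituent for another at the same place, so the expectation rests on these two steps alone.

For compound 4 the expected step of a 1.1-fold lower number from compound 2 to compound 4 (0.06 log units; within the scatter) is therefore no change beyond the scatter. Compound 4 is estimated at 6500 nM in this assay, within the range 3500 nM to 12000 nM.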

Compound 4, half-maximal inhibitory concentration: 11000 nM
The estimate for compound 4 lay 1.7-fold (0.23 log units) below the measured number; the range from low to high includes it.
By their numbers in this assay, from the lowest: compounds 3, 1, 2 and 4 (each within the scatter of the next, the first and the last beyond it).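

In this assay the series now holds its first exchange of one substituent for another at a single place, methyl in place of chloro on the aromatic carbon para to a large group, which gives a 1.5-fold higher number from compound 2 to compound 4 (0.17 log units; within the scatter); methyl in place of hydrogen there gives a 1.7-fold higher number from compound 1 to compound 4 (0.24 log units; within the scatter). Hydrogen, chloro and methyl at this position thus stay within the scatter of one another, and methyl, the first group on this ring that is not a halogen, does not change that. No measurement shown accounts for these numbers.

As far as these compounds go, whether an amine, a carboxylic acid or a longer chain at this position would move the number beyond the scatter remains open. So does whether methyl at other places on this ring would give the same result.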